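Compound 3 to compound 4: one added methyl

This account rests on a few compounds, and the source may have more. Where it says the series, first, only, none or still open, it means among the compounds named here.

Measured in a functional assay on the whole organism (Abdomen) with Mus musculus as the target; a higher number here means that more compound is needed for the effect, a lower number that less compound is needed:
compound 1 `CCc1sc(C(C)C)nc1Cc1c[nH]cn1` gives 7.5 mg/kg
compound 2 `CCc1nc(C(C)c2c[nH]cn2)c(CC)s1` gives 16 mg/kg
compound 3 `CCc1nc(Cc2c[nH]cn2)sc1C` gives > 30 mg/kg

Compound 3 reads > 30 mg/kg and this is a limit of this assay, not a number, so it stands at the end of the range where the series can be read.

Compound 4 `CCc1nc(Cc2c[nH]cn2)sc1CC` differs from compound 3 by methyl in place of hydrogen on a saturated chain carbon bound to an aromatic carbon in the form of methyl in place of hydrogen on a saturated chain carbon bound to an aromatic carbon, which also reads as methyl to ethyl.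

For the measured compounds named here, no measured pair isolates this change. The nearest anchors are compound 1 at 7.5 mg/kg and compound 2 at 16 mg/kg, and both differ from compound 3 in more than one place. On those two values a moderate move towards less compound needed is expected in this assay, and the estimate is an at least 1.5-fold lower number from compound 3 to compound 4 (0.17 log units; that floor lies within the scatter), its size left loose by the limit. For compound 4 the estimated value is 20 mg/kg, with an expected range of 8 mg/kg to 45 mg/kg.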

Compound 4, dose for half-maximal effect: > 30 mg/kg
Compound 4 was reported as a limit; the forecaster's own chance of this, stated with the estimate: 30%; at least 1.5-fold (0.17 log units) between middle value and limit.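

No step can be read from compound 3 to compound 4 in this assay, as both results are limits: the limit of > 30 mg/kg in this assay, at which 2 of the 4 values shown sit.

The compounds shown leave open whether methyl in place of hydrogen on a saturated chain carbon bound to an aromatic carbon changes the dose needed at all.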